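A Hydroxyl Epimer and Cytotoxicity Toward P388 Cells

A few compounds are considered here, and "the series" means these few. Any claim that something is new, unique, unknown or untested is made for them only; others in the source may bear on it.

Compound 1, `C=C(C)[C@@H]1C(=O)C=C(C)[C@@H]2CC[C@H](C)C[C@@H]12`, is the unhydroxylated member of this small set. In a functional assay on P388 cells (Mus musculus) for cytotoxicity, read by MTT assay (a lower number here means that less compound is needed, a higher number that more compound is needed for the effect), compound 1 gives only > 50 ug/mL, which is a limit of the assay and not a number. Compound 2, `C=C(C)[C@@H]1C(=O)C=C(C)[C@]2(O)CC[C@H](C)C[C@@H]12`, carries a hydroxyl on the ring and in this assay compound 2 gives 3.69 ug/mL. Among the measured compounds shown here, that makes compound 2 the only compound with an actual number; the other value is a limit, (the limit of > 50 ug/mL in this assay, at which 1 of the 2 values shown sits).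

Compound 3, `C=C(C)[C@@H]1C(=O)C=C(C)[C@@]2(O)CC[C@H](C)C[C@@H]12`, is the unmeasured partner. Compared with compound 2, (the two compounds have the same atoms and bonds and differ only in configuration as drawn: 1 of 4 stereo elements differ; a stereocentre at a saturated ring carbon is drawn S in compound 2 and R in compound 3). No change between two measured compounds of the same kind has been followed here, so nothing tells how much a flip of configuration at this carbon should move the read-out. A step of a 1.6-fold higher number from compound 2 to compound 3 (0.21 log units; within the scatter) from compound 2 to compound 3 is expected, a modest loss that may not exceed the usual scatter. Compound 3 is therefore estimated at 6 ug/mL in this assay, with a plausible range from 2 ug/mL to 20 ug/mL.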

Compound 3, concentration for half-maximal effect: > 50 ug/mL
Compound 3 was reported as a limit; the forecaster's own chance of this, stated with the estimate: 15%; middle value at least 8.3-fold (0.92 log units) from the limit.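

Inverting one stereocentre at a saturated ring carbon gives an at least 13-fold higher number from compound 2 to compound 3 (1.13 log units; beyond the scatter) in this assay, so having a hydroxy on this carbon is not enough by itself, and its configuration matters as well. Nothing else separates this pair, which lets the large gap be tied to that single change in configuration: the fact that compounds 2 and 3 differ only in the configuration as drawn. Compound 1 and compound 3 both rest at a limit of the assay and not at a number, so the step between them cannot be read, and the hydroxy in the configuration of compound 3 brings no measurable gain over the unhydroxylated compound: the limit of > 50 ug/mL in this assay, at which 2 of the 3 values shown sit.

As far as these compounds go, the full size of the loss stays open, as a limit marks only where the reading stops and gives no value for compound 3. Also open, from the compounds shown here alone, is whether a different group on this carbon, such as a methoxy or an amine, would behave like the hydroxy of compound 2 in either configuration, and whether the same sensitivity to configuration would appear in cells other than those of this one assay.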